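Second chloro on the benzyl ring of compound 2

The source may report more compounds than this note shows. Statements on the series, on what has been measured and on what is new or still open speak of the compounds shown alone.

In a functional assay on SW-620 cells (Homo sapiens) for inhibition, read by MTT assay, with a stated time of 48 h (on this read-out higher numbers stand for weaker inhibition and lower numbers for stronger inhibition), compound 1 (`Cc1ccc(NC(=S)NC(=O)c2ccc(OCc3ccccc3)cc2)cc1-c1nc2ccccc2[nH]1`) gives 67100 nM. Compound 2 (`Cc1ccc(NC(=S)NC(=O)c2ccc(OCc3cccc(Cl)c3)cc2)cc1-c1nc2ccccc2[nH]1`) stands at > 100000 nM, which is a limit of the assay and not a number. Compound 3 (`Cc1ccc(NC(=S)NC(=O)c2ccc(OCc3cccc(Cl)c3Cl)cc2)cc1-c1nc2ccccc2[nH]1`) carries one further change, chloro in place of hydrogen on an aromatic carbon, ortho to a chloro group and ortho to a large group, turning 3-chlorobenzyl into 2,3-dichlorobenzyl. Among the compounds with values here, the one measured step of the same kind is an at least 1.4-fold higher number from compound 1 to compound 2 (0.17 log units; that floor lies within the scatter), and its floor lies within the scatter. On the strength of that step, no shift beyond the scatter is expected in this assay, and no direction can be assigned. The expected step is a number no higher from compound 2 to compound 3 (the limit leaves the size open). For compound 3 the estimate is 100000 nM, with an expected range from 40000 nM to 250000 nM, and a report as a limit is quite likely.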

Compound 3, half-maximal inhibitory concentration: > 100000 nM
Compound 3: only a limit was reported; the forecaster's own chance of this, stated with the estimate: 60%; the middle value lies on the limit itself.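

In this assay, on these data alone, adding a chloro ortho to a chloro group and ortho to a large group yields a second limit, so the step between compound 2 and compound 3 cannot be read and the effect of this change stays unknown. Measured against the unsubstituted benzyl, the comparison gives an at least 1.4-fold higher number from compound 1 to compound 3 (0.17 log units; that floor lies within the scatter), so 2,3-dichlorobenzyl, like 3-chlorobenzyl, is not separated from phenyl beyond the scatter. Compound 2 and compound 3 thus end on the same limit, and only compound 1 gives a number: the limit of > 100000 nM in this assay, at which 2 of the 3 values shown sit.

As far as these compounds go, it remains open how the read-out responds to a group other than chloro on this ring, such as methoxy or an amine. From the compounds shown here alone, whether any such group could move the value in either direction from that of compound 1 also remains open.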